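A few compounds are considered here, and "the series" means these few. Any claim that something is new, unique, unknown or untested is made for them only; others in the source may bear on it.

In an ADME assay on BCBL1 cells (Homo sapiens) for cytotoxicity, with a stated time of 7 days (a lower number here means that less compound is tolerated, a higher number that more compound is tolerated), compound 1 (`C=CCOc1nc(N)nc2c1ncn2/C=C1/CC1(CO)CO`) gives > 20000 nM, which is a limit of the assay and not a number. Compound 2 (`Nc1nc(N2CCCC2)c2ncn(/C=C3/CC3(CO)CO)c2n1`) gives > 20000 nM, likewise only a limit. Compound 2 therefore stands at the limit of > 20000 nM in this assay, at which 2 of the 2 values shown sit. The next structure, compound 3 (`Nc1nc(NC2CCCC2)c2ncn(/C=C3/CC3(CO)CO)c2n1`), carries cyclopentylamino in place of pyrrolidin-1-yl on an aromatic carbon. Among the measured compounds shown here, the one measured step at that carbon, a step that the two limits leave unreadable from compound 1 to compound 2, gives no size to carry over, so no change beyond the usual scatter is expected in this assay, in either direction. The estimated step is a number no higher from compound 2 to compound 3 (the limit leaves the size open). For compound 3 the expected value is 20000 nM, with an estimated range from 9000 nM to 40000 nM.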

Compound 3, half-maximal cytotoxic concentration: 71700 nM
For compound 3 the middle estimate is 3.6-fold (0.55 log units) below the measured one, outside the stated range (above it).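

No size can be read for the step to compound 3 from either compound 1 or compound 2, because each of those two gives only a limit and not a number: the limit of > 20000 nM in this assay, at which 2 of the 3 values shown sit. The compounds shown leave open how far compound 3 actually lies from compound 1 and compound 2.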